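This account rests on a few compounds, and the source may have more. Where it says the series, first, only, none or still open, it means among the compounds named here.

Measured compounds:
compound 1 `COc1ccc2nccc(C(=O)NCCC3CCN(S(=O)(=O)NC(=O)NC4CCCCC4)CC3)c2c1`: 15%
compound 2 `COc1ccc2nccc(C(=O)NCCC3CCN(S(=O)(=O)NC(=O)NC[C@@H]4C[C@@H]5C=C[C@@H]4C5)CC3)c2c1`: 10%
compound 3 `O=C(NC1CCCCC1)NS(=O)(=O)N1CCC(CCNC(=O)c2cccc3c2OCCO3)CC1`: 34%

In a functional assay on the whole organism (blood) with Rattus norvegicus as the target, with stated times of 24 h and 1 h, at a dose of 5 mg/kg by the intraperitoneal route (a lower number here means a weaker effect, a higher number a stronger effect of the compound at the dose given), compound 1 gives 15% and compound 2 gives 10%; the change a group of 8 heavy atoms (8 carbon; 2 five-membered non-aromatic rings of carbon only) in place of a group of 6 heavy atoms (6 carbon; one six-membered non-aromatic ring of carbon only), on an amide-type nitrogen made the step of a number 5 percentage points lower from compound 1 to compound 2 (within the scatter). The cores of compound 1 and compound 3 differ by 2,3-dihydro-1,4-benzodioxin-5-yl in place of 6-methoxyquinolin-4-yl on a carbonyl carbon, and that change made the step of a number 19 percentage points higher from compound 1 to compound 3 (beyond the scatter), so compound 3 at 34% stands highest of the three.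

Compound 4 `O=C(NC[C@@H]1C[C@@H]2C=C[C@@H]1C2)NS(=O)(=O)N1CCC(CCNC(=O)c2cccc3c2OCCO3)CC1` is not yet measured. It carries the change (a group of 8 heavy atoms (8 carbon; 2 five-membered non-aromatic rings of carbon only) in place of a group of 6 heavy atoms (6 carbon; one six-membered non-aromatic ring of carbon only), on an amide-type nitrogen), the same change as from compound 1 to compound 2, on the core of compound 3. For the measured compounds named here, the expected step for compound 4 in this assay is a number 5 percentage points lower from compound 3 to compound 4 (within the scatter), resting on the single earlier step of a number 5 percentage points lower from compound 1 to compound 2 (within the scatter), which stayed within the scatter. Going by the values given here, compound 4 is therefore estimated at 29%, with a range from 15% to 42% given the single precedent.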

Compound 4, a percentage reported as activity, at one dose (the size of the read-out at that dose, not a potency): 11%
For compound 4 the middle estimate is 18 percentage points above the measured one; the measured number lies below the stated range.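

In this assay, replacing cyclohexyl with the group of 8 heavy atoms on the amide-type nitrogen gave a number 23 percentage points lower from compound 3 to compound 4 (beyond the scatter), so the size of the step did not carry over from the earlier core: the same change on two cores in this assay, a number 5 percentage points lower (within the scatter) from compound 1 to compound 2 and a number 23 percentage points lower (beyond the scatter) from compound 3 to compound 4, 18 percentage points apart, beyond the scatter of two such steps. The reverse reading gives the same result for the change on the carbonyl carbon, with a number 1 percentage points higher from compound 2 to compound 4 (within the scatter): the same change on two cores in this assay, a number 19 percentage points higher (beyond the scatter) from compound 1 to compound 3 and a number 1 percentage points higher (within the scatter) from compound 2 to compound 4, 18 percentage points apart, beyond the scatter of two such steps. The two changes are therefore not additive across these four compounds, but a single square gives neither a reason for this nor a rule for other cores.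

Open, going by these compounds, is how either nitrogen group would behave with a plain phenyl on the carbonyl carbon. Also open, on these data alone, is whether cyclopentyl on the amide-type nitrogen would follow cyclohexyl or the group of 8 heavy atoms.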